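Swapping the aryl group on the shared core of compound 1

A few compounds are considered here, and "the series" means these few. Any claim that something is new, unique, unknown or untested is made for them only; others in the source may bear on it.

Compound 1 `COc1ccc(C2=C(c3ccc(SC)cc3)CC3CCCN3C2=O)cc1O` is the weakest growth inhibitor of the three compounds measured: in a functional assay on SW-620 cells (Homo sapiens) for cytotoxicity (a higher number here means a weaker inhibitor of growth, a lower number a stronger inhibitor of growth), compound 1 gives 20000 nM. Compound 2 `COc1ccc(C2=C(c3ccc(SC)cc3)CC3CCCN3C2=O)cc1C` gives 500 nM and compound 3 `COc1ccc(C2=C(c3ccc(SC)cc3)CC3CCCN3C2=O)cc1` gives 3000 nM, so compound 1 stands at the top of the numbers, with compound 3 nearest and compound 2 furthest away.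

Compound 4 `CSc1ccc(C2=C(c3ccc(Br)cc3)C(=O)N3CCCC3C2)cc1` differs from compound 1 in one place: 4-bromophenyl in place of 3-hydroxy-4-methoxyphenyl on a double-bonded ring carbon. For the measured compounds named here, two measured steps bear on this change, both of which alter the same aryl group. The step of a 6.7-fold lower number from compound 1 to compound 3 (0.82 log units; beyond the scatter) shows that losing the hydroxy group alone already lowers the number, and the step of a 40-fold lower number from compound 1 to compound 2 (1.60 log units; beyond the scatter) shows that a non-polar group in that position lowers it further. Going by the values given here, the exchange of the methoxy-bearing ring for a 4-bromophenyl ring goes beyond either of those steps, and no measured pair covers the bromine itself, so the size is uncertain, but the direction is expected to be downward, beyond the scatter.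

Compound 4 is therefore expected to give about 2000 nM in this assay, within a range of 500 nM to 8000 nM, which would mean an estimated step of a 10-fold lower number from compound 1 to compound 4 (1.00 log units; beyond the scatter).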

Compound 4, concentration for 50% growth inhibition: 7000 nM
The estimate for compound 4 lay 3.5-fold (0.54 log units) below the measured number, within the range that was stated.
By their numbers in this assay, from the lowest: compound 2; then compound 3; then compound 4; then compound 1.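

In this assay, 4-bromophenyl in place of 3-hydroxy-4-methoxyphenyl on this double-bonded ring carbon gives a 2.9-fold lower number from compound 1 to compound 4 (0.46 log units; beyond the scatter) here, so a ring with no hydrogen-bond donor or acceptor still improves on the hydroxy-bearing ring of compound 1, though only modestly. The new compound also shows that removing the hydroxy group is not the only thing that matters at this position: bromo in place of methoxy gives a 2.3-fold higher number from compound 3 to compound 4 (0.37 log units; beyond the scatter) and 4-bromophenyl in place of 4-methoxy-3-methylphenyl gives a 14-fold higher number from compound 2 to compound 4 (1.15 log units; beyond the scatter), leaving both hydroxy-free methoxy-bearing rings ahead of the bromo ring. No measurement at hand explains why the methoxy-bearing rings give lower numbers than the 4-bromophenyl ring.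

From the compounds shown here alone, whether a methyl group on the 4-bromophenyl ring would lower the number, as the methyl group of compound 2 does relative to compound 3, remains open. So does whether an amine or a carboxylic acid on this aryl ring would follow the hydroxy group of compound 1 or the methyl group of compound 2.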